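Fluoro on the oxindole-side ring of a bis-indolyl series

The source may hold more compounds than are shown below. What is called first, only, known or untested is meant among the compounds shown, and "the series" means these compounds.

Among the measured compounds shown here, compound 1 `COc1cccc2[nH]cc(C3(c4c[nH]c5cccc(OC)c45)C(=O)Nc4ccccc43)c12` is one of two compounds measured in a functional assay on A549 cells (Homo sapiens) for cytotoxicity, read by MTT assay, with a stated time of 48 h; a lower number here means a stronger inhibitor, a higher number a weaker inhibitor. In this assay compound 1 gives 15300 nM, the highest of the two numbers. Its nearest neighbour is compound 2 `O=C1Nc2ccc(F)cc2C1(c1c[nH]c2ccccc12)c1c[nH]c2ccccc12`, which in this assay gives 12700 nM; the two values lie within the scatter of each other, so no order between them can be stated. For the measured compounds named here, no pair of measured compounds differs in a single place, so no measured step is available.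

Compound 3 `COc1cccc2[nH]cc(C3(c4c[nH]c5cccc(OC)c45)C(=O)Nc4ccc(F)cc43)c12` differs from compound 1 by fluoro in place of hydrogen on an aromatic carbon. Going by the values given here, with no measured step for this change, nothing supports a shift beyond the scatter in either direction. The estimate for compound 3 in this assay is therefore 13000 nM, with a range from 6000 nM to 30000 nM, corresponding to an expected step of a 1.2-fold lower number from compound 1 to compound 3 (0.07 log units; within the scatter) that stays within the scatter.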

Compound 3, half-maximal inhibitory concentration: 7800 nM
The estimate for compound 3 lay 1.7-fold (0.22 log units) above the measured number, and the stated range covers the measured number.
By their numbers in this assay, from the lowest: compounds 3, 2 and 1 (each within the scatter of the next).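

In this assay the series now has its first single-place comparison, with a 2.0-fold lower number from compound 1 to compound 3 (0.29 log units; within the scatter) as the reading for fluoro in place of hydrogen on an aromatic carbon. This carbon, meta to a fused ring and para to a fused ring on the core of compound 1, therefore takes a fluoro without a shift that can be told from the scatter. No measurement bears on the reason for this reading.

As far as these compounds go, one step at one carbon sets no trend, and it remains open whether a larger or differently built group here, such as an amine, a nitrile or a carboxylic acid, would move the number beyond the scatter. From the compounds shown here alone, the same fluoro exchange on the core without the two methoxy groups also remains open, as compound 2 has no partner lacking the fluoro.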